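This account rests on a few compounds, and the source may have more. Where it says the series, first, only, none or still open, it means among the compounds named here.

Compound 1, `CC#CC(CC(=O)O)c1ccc(OCc2ccc(C(=O)N3CCN(Cc4ccccc4)CC3)s2)cc1`: 155 nM in a functional assay on HEK293 cells for agonist activity at Free fatty acid receptor 1 (Homo sapiens), read by fluorescence and calcium flux; on this read-out higher numbers stand for an effect only at larger amounts of compound and lower numbers for an effect already at smaller amounts
Compound 2, `CC#CC(CC(=O)O)c1ccc(OCc2ccc(C(=O)N3CCN(c4ccc(C(C)(C)C)cc4)CC3)s2)cc1`: 417 nM in this assay

The two compounds share one core and differ only in the group carried on an amine nitrogen in a ring. Of the two numbers shown, compound 2 has the higher one; its nearest neighbour is compound 1, and that step, a 2.7-fold higher number from compound 1 to compound 2 (0.43 log units; beyond the scatter), lies beyond the scatter. Compound 3, `CC#CC(CC(=O)O)c1ccc(OCc2ccc(C(=O)N3CCN(c4ccccc4[N+](=O)[O-])CC3)s2)cc1`, is not yet measured. It differs from compound 2 in one place: 2-nitrophenyl in place of 4-(tert-butyl)phenyl on an amine nitrogen in a ring. Going by the values given here, the only measured step that bears on this change is the exchange of groups on that same ring nitrogen, which gave a 2.7-fold higher number from compound 1 to compound 2 (0.43 log units; beyond the scatter). Among the compounds with values here, no measured compound carries a nitrophenyl group there, so the direction of the new step is uncertain. Since compound 2 gives 417 nM and the change is of the same kind, compound 3 is expected to stay near it, as a 1.2-fold lower number from compound 2 to compound 3 (0.08 log units; within the scatter), with an estimate of 350 nM in the range 120 nM to 1000 nM.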

Compound 3, half-maximal effective concentration: 94 nM
For compound 3 the middle estimate is 3.7-fold (0.57 log units) above the measured one; measured number below the stated range.
By their numbers in this assay, from the lowest: compounds 3 and 1 (each within the scatter of the next); then compound 2.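

In this assay, the higher number of compound 2 does not hold for every substituted phenyl group on this ring nitrogen: 2-nitrophenyl in place of 4-(tert-butyl)phenyl gives a 4.4-fold lower number from compound 2 to compound 3 (0.65 log units; beyond the scatter). Against benzyl, 2-nitrophenyl gives a 1.6-fold lower number from compound 1 to compound 3 (0.22 log units; within the scatter), so these two groups cannot be told apart here, even though only one of them carries a nitro group.

Going by these compounds, it remains open whether the nitro group itself matters: a plain phenyl group, or a phenyl group carrying an amine or a methoxy group instead of the nitro group, would test this. Nothing measured here gives a reason for either step.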